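Removing one fluorine from the difluorophenyl chalcone

A few compounds are considered here, and "the series" means these few. Any claim that something is new, unique, unknown or untested is made for them only; others in the source may bear on it.

Compound 1 `O=C(COc1ccc(C(=O)/C=C/c2ccccc2Cl)cc1)N[C@H]1CCOC1=O` gives 17400 nM in a functional assay on MCF7 cells (Homo sapiens) for antiproliferative activity, read by MTT assay, with a stated time of 72 h; a lower number here means a stronger inhibitor, a higher number a weaker inhibitor. Compound 2 `O=C(COc1ccc(C(=O)/C=C/c2ccc(F)c(F)c2)cc1)N[C@H]1CCOC1=O` gives > 64000 nM in this assay, which is a limit and not a number. The step of an at least 3.6-fold higher number from compound 1 to compound 2 (0.56 log units; beyond the scatter) is thus a loss of at least modest size, bounded by the limit of > 64000 nM in this assay, at which 1 of the 2 values shown sits. Compound 3 `O=C(COc1ccc(C(=O)/C=C/c2ccc(F)cc2)cc1)N[C@H]1CCOC1=O` differs from compound 2 by hydrogen in place of fluoro on an aromatic carbon, the same change read one bond further out being 3,4-difluorophenyl to 4-fluorophenyl. Going by the values given here, no measured step covers this change; the one measured step swaps the whole aryl group. The expected step of an at least 1.2-fold lower number from compound 2 to compound 3 (0.10 log units; that floor lies within the scatter) is small, within the scatter. Compound 3 is estimated at 50000 nM, with a range from 15000 nM to 150000 nM.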

Compound 3, half-maximal inhibitory concentration: > 64000 nM
Compound 3: only a limit was reported (the forecaster's own chance of this, stated with the estimate: 55%); middle value at least 1.2-fold (0.10 log units) away from the limit.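

Removing the fluoro from the 3,4-difluorophenyl group leaves compound 3 at a limit, as compound 2 is, so the step between them cannot be read. The 4-fluorophenyl group also gives a loss against 2-chlorophenyl: an at least 3.6-fold higher number from compound 1 to compound 3 (0.56 log units; beyond the scatter). In this assay, both fluorinated compounds therefore end at the same boundary, and only compound 1 gives a number: the limit of > 64000 nM in this assay, at which 2 of the 3 values shown sit.

As far as these compounds go, whether the gain of compound 1 belongs to the chloro group or to its place on the ring stays open. A 4-chlorophenyl or 2-fluorophenyl group would separate the two.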